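A few compounds are considered here, and "the series" means these few. Any claim that something is new, unique, unknown or untested is made for them only; others in the source may bear on it.

Measured in a functional assay on MDA-MB-231 cells (Homo sapiens) for antiproliferative activity, read by sulforhodamine B assay, with a stated time of 72 h; on this read-out higher numbers stand for weaker inhibition and lower numbers for stronger inhibition:
compound 1 `COc1c(OC(C)C)cc2occ(-c3csc4ccccc34)c(=O)c2c1O`: > 10000 nM (a limit)
compound 2 `COc1c(O)cc2occ(-c3csc4ccccc34)c(=O)c2c1O`: > 10000 nM (a limit)
compound 3 `COc1cc2occ(-c3csc4ccccc34)c(=O)c2c(OC)c1OC`: 820 nM

Going by the values given here, compound 3 gives the only actual number, 820 nM. The entries for compound 1 and compound 2 are limits, so neither offers a number to compare with it.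

Compound 4 `CCOc1c(OC)cc2occ(-c3csc4ccccc34)c(=O)c2c1OC` is the next to read. It differs from compound 3 by methyl in place of hydrogen on a saturated chain carbon bound to an oxygen on an aromatic ring, which is methoxy to ethoxy.

Among the compounds with values here, the one measured step on an oxygen on an aromatic ring is a step that the two limits leave unreadable from compound 1 to compound 2, and it supplies no size to carry over. All it offers is the limit of > 10000 nM in this assay, at which 2 of the 3 values shown sit.

With compound 3 at 820 nM as the only anchor, no step beyond the scatter is expected in this assay. The estimated change is a 1.2-fold higher number from compound 3 to compound 4 (0.09 log units; within the scatter), and the range is kept wide for lack of a readable step. Compound 4 is expected at 1000 nM, with an estimated range of 300 nM to 4000 nM.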

Compound 4, half-maximal inhibitory concentration: 5200 nM
Compound 4: the middle estimate sits 5.2-fold (0.72 log units) below what was measured; the whole stated range lies below it.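

Methoxy to ethoxy gives the first readable step in this assay: a 6.3-fold higher number from compound 3 to compound 4 (0.80 log units; beyond the scatter). The earlier step, between compound 1 and compound 2, cannot be read, whereas this one shows that a single methyl added on a saturated chain carbon bound to an oxygen on an aromatic ring is enough to move the read-out beyond the scatter, toward weaker inhibition. Nothing measured here accounts for this change.

On these data alone, it remains open whether a longer chain such as propoxy would weaken inhibition further, or whether an amine at the end of that chain would reverse the direction. One step also cannot say whether the same methyl would have a similar effect on the other methoxy groups of compound 3.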